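From Methyl to Chloro on an Aromatic Carbon

This account rests on a few compounds, and the source may have more. Where it says the series, first, only, none or still open, it means among the compounds named here.

Compound 1 `O=S(=O)(Nc1ccc2cc[nH]c2c1)c1ccc(F)cc1` in a functional assay on MCF7 cells (Homo sapiens) for antiproliferative activity, read by MTT assay, with a stated time of 24 h; a higher number here means a weaker inhibitor, a lower number a stronger inhibitor: 30900 nM
Compound 2 `Cc1ccc(S(=O)(=O)Nc2ccc3cc[nH]c3c2)cc1` in this assay: 37200 nM

These two numbers lie within the scatter of each other, so compound 2 stands level with compound 1. Compound 3 `O=S(=O)(Nc1ccc2cc[nH]c2c1)c1ccc(Cl)cc1` carries chloro in place of methyl on an aromatic carbon. For the measured compounds named here, one measured step bears on this change: a 1.2-fold higher number from compound 1 to compound 2 (0.08 log units; within the scatter), which swapped methyl for fluoro. Going by the values given here, with only that small step to go on, no change beyond the scatter is expected in this assay. The expected step is a 1.1-fold lower number from compound 2 to compound 3 (0.05 log units; within the scatter). Compound 3 is estimated at 33000 nM, with an expected range from 17000 nM to 62000 nM.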

Compound 3, half-maximal inhibitory concentration: 54000 nM
The estimate for compound 3 lay 1.6-fold (0.21 log units) below the measured number; measured number inside the range.
By their numbers in this assay, from the lowest: compounds 1, 2 and 3 (each within the scatter of the next).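

Chloro in place of methyl on this aromatic carbon gave a 1.5-fold higher number from compound 2 to compound 3 (0.16 log units; within the scatter) in this assay and chloro in place of fluoro gave a 1.7-fold higher number from compound 1 to compound 3 (0.24 log units; within the scatter) in the same read-out. With fluoro, methyl and chloro now compared at this position, para to a large group, both new steps stay within the scatter, so these three groups cannot be told apart here. No evidence is available to explain these numbers. The compounds shown leave open whether an amine or a carboxylic acid at this position would give a step beyond the scatter.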